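Swapping piperidin-1-yl for phenyl on compound 3

A few compounds are considered here, and "the series" means these few. Any claim that something is new, unique, unknown or untested is made for them only; others in the source may bear on it.

Measured so far in a physicochemical assay for solubility, in phosphate buffer, at pH 7.4; on this read-out lower numbers stand for lower solubility and higher numbers for higher solubility:

- Compound 1 `OCC1CCN(c2nccnc2Oc2ccc(Nc3nc4ccccc4s3)cc2)CC1` gives 6000 nM
- Compound 2 `OCC1CCN(c2nccnc2OC2CN(c3cnc4ccccc4n3)C2)CC1` gives 500000 nM
- Compound 3 `c1ccc2nc(N3CC(Oc4nccnc4N4CCCCC4)C3)ccc2c1` gives < 1000 nM

The two numbers at the top of this set are far apart, with compound 1 at 6000 nM and compound 2 higher at 500000 nM. These two compounds differ in more than one place, so their gap says little about any single change.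

Compound 3 reads < 1000 nM, which is a limit of this assay and not a number. From the compounds shown here alone, it therefore marks where the measurable range ends, and the true value of compound 3 remains unknown.

Compound 4 `c1ccc(-c2nccnc2OC2CN(c3ccc4ccccc4n3)C2)cc1` has not been measured yet. It differs from compound 3 in one place: phenyl in place of piperidin-1-yl on an aromatic carbon. This puts phenyl in place of piperidin-1-yl on an aromatic carbon of a six-membered aromatic ring with 2 nitrogen.

Among the compounds with values here, no pair of measured compounds differs in only one place, so the data offer no direct precedent for this swap. The expectation rests on compound 3 alone, whose < 1000 nM is a limit.

In this assay, no step beyond the usual scatter is expected, and the estimated step is a step that the limit leaves unreadable from compound 3 to compound 4.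

The estimate for compound 4 is 900 nM, with an expected range of 300 nM to 3000 nM.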

Compound 4, solubility: < 1000 nM
Compound 4 ended at the assay's limit (the forecaster's own chance of this, stated with the estimate: 60%); the middle value is on the limit's open side.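

Compound 3 and compound 4 both sit at the limit of this assay, so no step can be read for phenyl in place of piperidin-1-yl on an aromatic carbon: the limit of < 1000 nM in this assay, at which 2 of the 4 values shown sit.

The compounds shown leave open where the true values of compound 3 and compound 4 lie, and whether this swap changes the read-out at all.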